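This account rests on a few compounds, and the source may have more. Where it says the series, first, only, none or still open, it means among the compounds named here.

Notes on the series in a functional assay on PC-3 cells (Homo sapiens) for cytotoxicity, read by WST assay, with a stated time of 72 h (on this read-out lower numbers stand for stronger inhibition and higher numbers for weaker inhibition), follow. Compound 1 (`O=C1Nc2c(ccc(F)c2F)C1(c1ccncc1)c1ccc(O)cc1`) gives 110 nM as the only number shown for it, and a further entry carries no single number. Compound 2 (`O=C1Nc2c(ccc(F)c2F)C1(c1ccc(O)cc1)C1CCCCC1`) gives 9.2 nM; 32 nM; > 1000 nM (3 entries) as a wide spread of entries. The last of these entries is a limit of the assay and not a number. Compound 3 (`O=C1Nc2c(ccc(F)c2F)C1(CC1CCCCC1)c1ccc(O)cc1`) has not yet been measured. Its change from compound 1 is (cyclohexylmethyl in place of pyridin-4-yl on a saturated ring carbon): cyclohexylmethyl in place of pyridin-4-yl on a saturated ring carbon.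

Going by the values given here, no measured step isolates this change. In this assay a small step towards lower numbers is expected, possibly none beyond the scatter. Among the compounds with values here, the only support is compound 2 (the several entries of compound 2 in this assay, 9.2 nM; 32 nM; > 1000 nM (3 entries)) with its non-aromatic ring of carbon only, and it is a weak guide given the limit among its entries. The expected change is (a 1.6-fold lower number from compound 1 to compound 3 (0.20 log units; within the scatter)) and it is an estimate with a wide margin. For compound 3 the estimate is 70 nM with an expected range from 12 nM to 500 nM for a measurement of this kind.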

Compound 3, half-maximal inhibitory concentration: > 1000 nM
Compound 3: a limit, no number; the forecaster's own chance of this, stated with the estimate: 15%; middle value at least 14-fold (1.15 log units) from the limit.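

In this assay, replacing pyridin-4-yl with cyclohexylmethyl on this saturated ring carbon gives an at least 9.0-fold higher number from compound 1 to compound 3 (0.95 log units; beyond the scatter), so this position is clearly sensitive to the change and the step lies beyond the usual scatter. From the compounds shown here alone, compound 3 gives > 1000 nM, which is a limit of the assay and not a number, so the step has a lower bound only and its full size remains unknown. Compound 2, with a non-aromatic ring of carbon only at the same carbon, could not show how such a replacement would read out, whereas compound 3 now gives a first clear sign against cyclohexylmethyl here, with compound 2 still an unsettled case: the several entries of compound 2 in this assay, 9.2 nM; 32 nM; > 1000 nM (3 entries)

The step exchanges an aromatic ring holding a hetero atom for a non-aromatic ring of carbon only and also changes how that ring is attached, and the compounds shown do not separate these two changes. Going by these compounds, whether a benzyl group or a piperidin-4-yl ring on this carbon would stay nearer to compound 1 or fall towards compound 3 remains open, which would show which part of the change matters.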